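Bromo in Place of Nitro: An Expectation for Compound 4

This account rests on a few compounds, and the source may have more. Where it says the series, first, only, none or still open, it means among the compounds named here.

Measured in an assay on isolated protein for inhibition of lysosomal alpha-glucosidase (Homo sapiens), read by fluorescence, with stated times of 5 min and 45 min; on this read-out higher numbers stand for weaker inhibition and lower numbers for stronger inhibition:
Compound 1 `O=C1Cc2cc(S(=O)(=O)N3CCNCC3)ccc2N1`: "not active" (no number reported)
Compound 2 `O=C1Cc2cc(S(=O)(=O)N3CCN(c4ccc([N+](=O)[O-])cc4)CC3)ccc2N1`: 3660 nM
Compound 3 `O=C1Cc2cc(S(=O)(=O)N3CCN(c4ccc(Cl)cc4)CC3)ccc2N1`: 94300 nM

Within the data shown here, compound 2 stands at the lowest of the two numbers, and its only neighbour with a number is compound 3, reached through a 26-fold higher number from compound 2 to compound 3 (1.41 log units; beyond the scatter); compound 1 gave no number at all. Compound 4 `O=C1Cc2cc(S(=O)(=O)N3CCN(c4ccc(Br)cc4)CC3)ccc2N1` differs from compound 2 by bromo in place of nitro on an aromatic carbon. Among the measured compounds shown here, the one measured step that bears on this is a 26-fold higher number from compound 2 to compound 3 (1.41 log units; beyond the scatter), a large move towards weaker inhibition when a halogen replaces the nitro. A similar change is therefore expected for compound 4, with a 16-fold higher number from compound 2 to compound 4 (1.21 log units; beyond the scatter) in this assay. Compound 4 is estimated at 60000 nM, with a range from 15000 nM to 250000 nM.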

Compound 4, half-maximal inhibitory concentration: "not active" (no number reported)
Compound 4: no number reported; the estimate stays without a comparison.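

Among these compounds, compound 4 came back without a number, so no step from compound 2 or compound 3 to compound 4 can be read. The compounds shown leave open how far the bromo of compound 4 stands from the chloro of compound 3. No evidence bearing on this result is at hand.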